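Chain-end amides and esters on a weak series

A few compounds are considered here, and "the series" means these few. Any claim that something is new, unique, unknown or untested is made for them only; others in the source may bear on it.

Compound 3 `CCCCCCCCCCSc1nnc(Cc2nn(C)c(=O)c3ccccc23)n1C` carries a plain saturated chain on the sulfur of the shared core. For the measured compounds named here, in an assay on isolated protein (Mus musculus) for inhibition of IL15-IL15 receptor (Homo sapiens), read by resazurin assay, with stated times of 30 min and 2.5 days (a higher number here means a weaker inhibitor, a lower number a stronger inhibitor), compound 3 gives 7600 nM, the lowest of the three numbers measured so far, though both other values sit within the scatter of it. Compound 1 `Cn1c(Cc2nn(C)c(=O)c3ccccc23)nnc1SCCCC(=O)Nc1ccc(Cl)cc1Cl` gives 9800 nM in this assay, and compound 2 `Cn1c(Cc2nn(C)c(=O)c3ccccc23)nnc1SCCCCCCCCCCC(=O)Oc1ccc(Cl)cc1Cl` gives 8700 nM.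

Compound 4 `Cn1c(Cc2nn(C)c(=O)c3ccccc23)nnc1SCCCCCCCC(=O)Nc1ccc(O)cc1O` differs from compound 3 by (2,4-dihydroxyphenyl)carbamoyl in place of propyl on a saturated chain carbon, seven bonds along the chain from a sulfur. Going by the values given here, two measured steps concern an aryl carbonyl group at the chain end: a 1.3-fold lower number from compound 1 to compound 3 (0.11 log units; within the scatter) and a 1.1-fold lower number from compound 2 to compound 3 (0.06 log units; within the scatter). Both lie within the scatter, so neither the dichlorophenyl amide three bonds from the sulfur nor the dichlorophenyl ester shifted the number. Among the compounds with values here, compound 4 repeats this kind of change with a dihydroxyphenyl amide seven bonds along the chain from the sulfur; no measured pair separates ring hydroxyls from ring chlorines. The expected step is therefore none beyond the scatter, a 1.2-fold higher number from compound 3 to compound 4 (0.07 log units; within the scatter). For compound 4 the estimate is 9000 nM, with a range from 4500 nM to 18000 nM.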

Compound 4, half-maximal inhibitory concentration: 17000 nM
Compound 4: the middle estimate sits 1.9-fold (0.28 log units) below what was measured; low and high end bracket the measured number.
By their numbers in this assay, from the lowest: compounds 3, 2, 1 and 4 (each within the scatter of the next, the first and the last beyond it).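

For the compounds shown here, at the saturated chain carbon seven bonds along the chain from a sulfur, (2,4-dihydroxyphenyl)carbamoyl in place of propyl gives the only step in this set that passes the scatter in this assay: a 2.2-fold higher number from compound 3 to compound 4 (0.35 log units; beyond the scatter). The two aryl carbonyl steps to compound 3 stayed within the scatter, so this change alone shows that an aryl amide at a chain end can move the number, here towards a weaker inhibitor, though only modestly. No available measurement accounts for the shift.

The compounds shown do not separate the ring hydroxyls from the amide or from the chain length, as no matched partner isolates any of them. On these data alone, whether a carboxylic acid or a primary amine at the chain end would move the number in either direction remains open.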